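This account rests on a few compounds, and the source may have more. Where it says the series, first, only, none or still open, it means among the compounds named here.

Of the compounds shown here, three have been measured in a functional assay on SU-DHL-6 cells (Homo sapiens) for antiproliferative activity, read by MTT assay (on this read-out lower numbers stand for stronger inhibition and higher numbers for weaker inhibition), and the numbers are spread widely. Compound 1 `COc1ncc(-c2ccc3ncnc(N[C@H]4CCCN(C(=O)C(F)(F)F)C4)c3c2)cc1[N+](=O)[O-]` gives 127000 nM in this assay. Compound 3 `CCOC(=O)CN1CCC[C@H](Nc2ncnc3ccc(-c4cnc(OC)c(C(F)(F)F)c4)cc23)C1` gives 230 nM. Compound 2 `COc1ncc(-c2ccc3ncnc(N[C@H]4CCCN(C(=O)CCBr)C4)c3c2)cc1C#N` gives 15 nM, the lowest of the three and therefore the strongest inhibitor of cell growth in this set; its gap to compound 3 and its gap to compound 1 both lie well beyond the usual scatter of repeated measurements.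

Compound 4 `COc1ncc(-c2ccc3ncnc(N[C@H]4CCCN(C(=O)C5CCOCC5)C4)c3c2)cc1C#N` has not yet been measured. It shares the whole of compound 2 apart from one place: oxan-4-yl in place of 2-bromoethyl on a carbonyl carbon

Among the measured compounds shown here, no pair of measured compounds differs at only that one place, so the effect of this particular change has not been seen directly. For the measured compounds named here, compound 2 is the only compound carrying the 2-bromoethyl group, and it is also the one with the lowest number. Without a measured comparison, the expectation is that compound 4 loses some potency, and the estimated step of a 13-fold higher number from compound 2 to compound 4 (1.12 log units; beyond the scatter) is a moderate rise beyond the scatter. Compound 4 is therefore expected to give about 200 nM in this assay, with a plausible range from 40 nM to 1500 nM.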

Compound 4, half-maximal inhibitory concentration: 150 nM
The estimate for compound 4 lay 1.3-fold (0.12 log units) above the measured number; measured number inside the range.
By their numbers in this assay, from the lowest: compound 2; then compounds 4 and 3 (each within the scatter of the next); then compound 1.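

In this assay, among the compounds shown here, putting oxan-4-yl in place of 2-bromoethyl on the carbonyl carbon gives a 10-fold higher number from compound 2 to compound 4 (1.00 log units; beyond the scatter), the first direct reading of a change at this place with the rest of the molecule held the same. The step lies beyond the scatter, so the group on this carbonyl carbon does affect the number, yet a group with a six-membered non-aromatic ring is tolerated well enough that compound 4 still gives 150 nM. Nothing measured here explains the size of this step.

The compounds shown leave open which part of the swap matters, the loss of the bromine or the arrival of the ring and its oxygen; a plain ethyl group on the same carbonyl carbon would speak to the bromine, and a cyclohexyl ring would speak to the oxygen. From the compounds shown here alone, it also remains open whether the same swap would give a step of similar size with a trifluoromethyl or nitro group in place of the nitrile on the shared core.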